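A Benzyl Swap at the Cytotoxicity Limit

The compounds below may be only part of what the source reports. "The series", "measured", "known", "first", "only" and "open" are said of these compounds alone.

In a toxicity assay on MT2 cells (Homo sapiens) for cytotoxicity (on this read-out higher numbers stand for lower toxicity in this test and lower numbers for higher toxicity in this test), compound 1 (`Cc1nc(C)c([C@H](OC(C)(C)C)C(=O)O)c(N2CCC(C)(C)CC2)c1-c1ccc2c(c1)CCN(Cc1ccc(F)cc1)C2`) gives >= 22000 nM, which is a limit of the assay and not a number. Compound 2 (`Cc1nc(C)c([C@H](OC(C)(C)C)C(=O)O)c(N2CCC(C)(C)CC2)c1-c1cnn(CCCc2ccc(F)cc2)c1`) gives >= 22000 nM, which is also a limit. Compound 1 thus stands at the limit of >= 22000 nM in this assay, at which 2 of the 2 values shown sit. Compound 3 (`Cc1nc(C)c([C@H](OC(C)(C)C)C(=O)O)c(N2CCC(C)(C)CC2)c1-c1ccc2c(c1)CCN(Cc1cccc(F)c1C)C2`) has not yet been measured. It differs from compound 1 on a saturated chain carbon bound to an amine nitrogen in a ring, where 3-fluoro-2-methylphenyl replaces 4-fluorophenyl (3-fluoro-2-methylphenyl in place of 4-fluorophenyl on a saturated chain carbon bound to an amine nitrogen in a ring). Going by the values given here, no measured step between compounds gives the size of such a change, so no shift beyond the scatter is expected in this assay, in either direction. The estimated step of a number no higher from compound 1 to compound 3 (the limit leaves the size open) is expected to stay within that scatter. This expectation rests on compound 1, with its limit of >= 22000 nM. Compound 3 is expected at 22000 nM, with an estimated range from 10000 nM to 45000 nM.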

Compound 3, half-maximal cytotoxic concentration: >= 24000 nM
Compound 3: only a limit was reported (the forecaster's own chance of this, stated with the estimate: 70%); middle value at least 1.0-fold (0.03 log units) from the limit.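

In this assay compound 3 gives >= 24000 nM, which is a limit of the assay and not a number. Compound 1 also stands at a limit, so the step between compound 1 and compound 3 cannot be read. What the compounds shown leave open is whether 3-fluoro-2-methylbenzyl in place of 4-fluorobenzyl changes cytotoxicity at all.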